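The source may report more compounds than this note shows. Statements on the series, on what has been measured and on what is new or still open speak of the compounds shown alone.

Compound 2 `CC(C)(C)NC(=O)NCCS(=O)(=O)NC(=O)c1ccc(Nc2nc(NC3(c4ccc(Cl)cc4)CC3)nc(OCC(F)(F)F)n2)cc1` carries a (tert-butyl)carbamoyl group on the amine nitrogen; in an ADME assay on microsomes from liver (Rattus norvegicus) for metabolic stability, with a stated time of 10 min (on this read-out higher numbers stand for a more stable compound and lower numbers for a less stable compound), compound 2 gives 93%. Compound 1 `CC(C)NCCS(=O)(=O)NC(=O)c1ccc(Nc2nc(NC3(c4ccc(Cl)cc4)CC3)nc(OCC(F)(F)F)n2)cc1` carries an isopropyl there instead, and in this assay compound 1 gives 100%. The step of a number 7 percentage points lower from compound 1 to compound 2 (within the scatter) is within the scatter, so the two compounds stand level and compound 2 has no measured neighbour that separates from it.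

Compound 3 `CC(C)(C)OC(=O)NCCS(=O)(=O)NC(=O)c1ccc(Nc2nc(NC3(c4ccc(Cl)cc4)CC3)nc(OCC(F)(F)F)n2)cc1` differs from compound 2 by tert-butoxy in place of (tert-butyl)amino on a carbonyl carbon. Going by the values given here, only one measured step exists, a number 7 percentage points lower from compound 1 to compound 2 (within the scatter); it concerns the amine nitrogen rather than the carbonyl carbon and is itself within the scatter, so it bears on the new step only loosely, as a sign that this end of the molecule has so far left this assay untouched. No change beyond the scatter is therefore expected. For compound 3 the expected value is 90%, with a range from 75% to 100%. The step of a number 3 percentage points lower from compound 2 to compound 3 (within the scatter) is expected to stay within the scatter.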

Compound 3, percent of the compound remaining: 93%
The estimate for compound 3 lay 3 percentage points below the measured number, and the stated range covers the measured number.
By their numbers in this assay, from the lowest: compounds 2, 3 and 1 (each within the scatter of the next).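

In this assay, tert-butoxy in place of (tert-butyl)amino on the carbonyl carbon gives no change at the digits printed from compound 2 to compound 3 (within the scatter), so exchanging the nitrogen of this group for oxygen, with the loss of its hydrogen-bond donor, does not separate the two compounds. With tert-butoxycarbonyl in place of isopropyl on the amine nitrogen, the reading is a number 7 percentage points lower from compound 1 to compound 3 (within the scatter), so a second carbonyl-bearing group also stands level with the isopropyl. No available evidence bears on why these readings stay level.

Still open, as far as these compounds go, is whether a group of a different kind on this amine nitrogen, such as a carboxylic acid, a primary amine or a longer chain, would separate from these three compounds. The compounds shown also leave open whether changes elsewhere on the shared core would do so.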